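The source may hold more compounds than are shown below. What is called first, only, known or untested is meant among the compounds shown, and "the series" means these compounds.

The study follows two compounds tested in a functional assay on the whole organism (blood, strain Wistar-Okamoto) with Rattus norvegicus as the target, with a stated time of 5 days; on this read-out lower numbers stand for an effect already at smaller amounts and higher numbers for an effect only at larger amounts of compound. Compound 1, with the structure `CC(C)(C)C(C)(C)/N=C(\NC#N)Nc1cccnc1`, gives in this assay a value of 50 mg/kg. Compound 2, with the structure `Cc1cccc(C)c1N/C(=N/C#N)NC(C)(C)C`, reaches in this assay only a limit of the method, > 50 mg/kg. Compound 2 thus stands at the edge of what the method reports, namely (the limit of > 50 mg/kg in this assay, at which 1 of the 2 values shown sits). Within the data shown here, no single-step pair among the measured compounds exists, so the two values show only that compound 1 has a number while compound 2 has a limit. Compound 3, with the structure `CCC(C)(C)N/C(=N\C#N)Nc1c(C)cccc1C`, has not been measured in this assay; it differs from compound 2 by methyl in place of hydrogen on a saturated chain carbon, two bonds along the chain from an amine nitrogen. Among the measured compounds shown here, no measured step in this assay tells how large a change such a methyl brings, so the estimated step that the limit leaves unreadable from compound 2 to compound 3 stays within the usual scatter. Compound 3 is expected to give in this assay about 65 mg/kg, within a range from 30 mg/kg to 150 mg/kg, with a real chance that only a limit is returned again.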

Compound 3, minimum effective dose: 50 mg/kg
Compound 3: middle estimate off by 1.3-fold (0.11 log units), on the high side; low and high end bracket the measured number.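

With the change from (tert-butyl)amino to (1,1-dimethylpropyl)amino, this assay now holds its first step at this position: methyl in place of hydrogen on a saturated chain carbon, two bonds along the chain from an amine nitrogen, gives a number no higher from compound 2 to compound 3 (the limit leaves the size open). Compound 3 returns a number, 50 mg/kg, so this added methyl leaves the series with a readable value on the shared core. Compound 2 remains at a limit of the method, so the step has a direction but no size: the limit of > 50 mg/kg in this assay, at which 1 of the 3 values shown sits.

On these data alone, how much the methyl itself contributes therefore remains unknown. Also open, as far as these compounds go, is whether a longer chain in its place, such as propyl, or a polar group such as a hydroxyl on that same chain carbon, would move the value in this assay at all.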